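The source may report more compounds than this note shows. Statements on the series, on what has been measured and on what is new or still open speak of the compounds shown alone.

Measured so far in a functional assay on HepG2 cells (Homo sapiens) for inhibition, read by MTT assay, with a stated time of 72 h; a higher number here means a weaker inhibitor, a lower number a stronger inhibitor:
- compound 1 `COc1cc(/C=C/C(=O)c2c(OC)cc(O)c(CC=C(C)C)c2O)ccc1O` gives 21700 nM
- compound 2 `COc1ccc(/C=C/C(=O)c2c(OC)cc(O)c(CC=C(C)C)c2O)cc1OC` gives 13800 nM

Compound 1 has a single measured neighbour and is not separated from it (a 1.6-fold lower number from compound 1 to compound 2 (0.20 log units; within the scatter)). The next compound is compound 3 `COc1cc(O)c(CC=C(C)C)c(O)c1C(=O)/C=C/c1ccc([N+](=O)[O-])cc1`, with the change 4-nitrophenyl in place of 4-hydroxy-3-methoxyphenyl on a double-bonded chain carbon bound to a double-bonded chain carbon and the core of compound 1 otherwise kept. Going by the values given here, the single measured step altered the same group that leaves here, and it stayed within the scatter. Among the compounds with values here, it covers only a small part of this change, since no measured compound carries 4-nitrophenyl, and the data give no direction. No step beyond the scatter is therefore expected in this assay, though with wide uncertainty. The estimated step is a 1.4-fold lower number from compound 1 to compound 3 (0.13 log units; within the scatter). For compound 3 the estimated value is 16000 nM, with an expected range from 6000 nM to 42000 nM.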

Compound 3, half-maximal inhibitory concentration: 12400 nM
Estimate against measurement, compound 3: 1.3-fold (0.11 log units) above, within the range that was stated.
By their numbers in this assay, from the lowest: compounds 3, 2 and 1 (each within the scatter of the next).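

In this assay, exchanging the whole 4-hydroxy-3-methoxyphenyl group for 4-nitrophenyl on a double-bonded chain carbon bound to a double-bonded chain carbon gives a 1.8-fold lower number from compound 1 to compound 3 (0.24 log units; within the scatter) and does not separate the two compounds. The earlier step touched only a methyl on an oxygen, whereas here both oxygen substituents of the leaving group are gone and a nitro group stands in the entering one, so a far larger edit at this place also stays inside the scatter. No measured property of these compounds bears on this result.

On these data alone, whether a 4-aminophenyl group, a 4-carboxyphenyl group or a saturated cyclohexyl ring at this place would separate from compound 1 remains open. The compounds shown contain no step beyond the scatter, so what can move the number in this series is also open.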